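The source may report more compounds than this note shows. Statements on the series, on what has been measured and on what is new or still open speak of the compounds shown alone.

Measured compounds:
- compound 1, `COc1cccc(S(=O)(=O)c2n[nH]c3ccc(N4CCN(C)CC4)cc23)c1`: 57 nM
- compound 2, `CN1CCN(c2cccc3c(S(=O)(=O)c4cccc5ccccc45)n[nH]c23)CC1`: 17 nM

In a functional assay on HeLa cells for antagonist activity at 5-hydroxytryptamine receptor 6 (Homo sapiens) (on this read-out higher numbers stand for weaker inhibition and lower numbers for stronger inhibition), compound 1 gives 57 nM, the higher of the two numbers recorded so far. The nearest neighbour is compound 2, which gives 17 nM in this assay, a lower number that lies beyond the usual scatter of repeated measurements; the two compounds differ in more than one place, so their values are simply set side by side here.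

Compound 3, `CN1CCN(c2ccc3[nH]nc(S(=O)(=O)c4cccs4)c3c2)CC1`, has not yet been measured. It differs from compound 1 in a single place: thiophen-2-yl in place of 3-methoxyphenyl on a sulfonyl sulfur. A smaller aromatic ring thus replaces a larger one on the sulfonyl sulfur, while the rest of the shared core is unchanged.

Among the compounds with values here, there is no measured pair in this set that isolates such a swap, so the expected step rests on compound 1 alone. Compound 3 is expected to stay close to compound 1 in this assay, with the step of a 1.4-fold higher number from compound 1 to compound 3 (0.15 log units; within the scatter) estimated as small and, if anything, toward a somewhat higher number. The estimate for compound 3 is therefore 80 nM, with a likely range from 25 nM to 250 nM.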

Compound 3, half-maximal inhibitory concentration: 331 nM
Beside the measured number, compound 3's estimate is 4.1-fold (0.62 log units) below it, outside the stated range (above it).
By their numbers in this assay, from the lowest: compound 2; then compound 1; then compound 3.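

In this assay the swap of 3-methoxyphenyl for thiophen-2-yl on the sulfonyl sulfur gives a 5.8-fold higher number from compound 1 to compound 3 (0.76 log units; beyond the scatter) and so shows that the group at this position matters, at least on the core of compound 1. Within the data shown here, the earlier compounds could not show this, since they differ in more than one place, whereas here the rest of the structure is held constant and only this group changes. The data do not explain the size of the step: the six-membered carbon ring gives way to a five-membered ring with a hetero atom, and the methoxy group is lost in the same swap, so these changes cannot be told apart.

It remains open which of these changes accounts for the step: phenyl would keep the six-membered ring without the methoxy group, while furan-2-yl would keep a five-membered ring with oxygen in place of sulfur. Going by these compounds, it is also open whether the same swap would give a step of similar size on the core of compound 2.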